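The source may hold more compounds than are shown below. What is called first, only, known or untested is meant among the compounds shown, and "the series" means these compounds.

Values measured in an ADME assay on MT4 cells (Homo sapiens) for cytotoxicity, read by spectrophotometry, with a stated time of 5 days (a higher number here means that more compound is tolerated, a lower number that less compound is tolerated), follow
compound 1 `CONC(=S)N/N=C1\C(=O)N(CN2CCN(c3ccc(OC)cc3)CC2)c2ccc(C)cc21` gives 324000 nM
compound 2 `COc1ccc(N2CCN(CN3C(=O)/C(=N\NC(=S)NO)c4cc(C)ccc43)CC2)cc1` gives 321000 nM
compound 3 `CCn1cc(C(=O)O)c(=O)c2cc(F)c(N3CCN(CN4C(=O)/C(=N\NC(=S)NOC)c5cc(C)ccc54)CC3)cc21` gives 238000 nM

Compound 1 stands level with compound 2 and compound 3, all three values lying within the scatter of one another. The step followed here leads to compound 4 `CONC(=S)N/N=C1\C(=O)N(CN2CCN(c3ccccc3)CC2)c2ccc(C)cc21` with hydrogen in place of methoxy on an aromatic carbon as the difference, hydrogen in place of methoxy on an aromatic carbon. For the measured compounds named here, no measured step touches that methoxy group. Going by the values given here, the one measured step, a 1.0-fold lower number from compound 1 to compound 2 (0.00 log units; within the scatter) at another place in the molecule, stays within the scatter. Compound 3 carries no 4-methoxyphenyl group, yet compound 3 at 238000 nM also lies within the scatter of compound 1. The expected change is a 1.1-fold lower number from compound 1 to compound 4 (0.03 log units; within the scatter) and nothing beyond the scatter is expected in this assay here. Compound 4 is estimated at 300000 nM (expected range 170000 nM to 500000 nM).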

Compound 4, half-maximal cytotoxic concentration: 276000 nM
Estimate against measurement, compound 4: 1.1-fold (0.04 log units) above; the range from low to high includes it.
By their numbers in this assay, from the lowest: compounds 3, 4, 2 and 1 (each within the scatter of the next).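

In this assay, for the compounds shown here, the change from 4-methoxyphenyl to phenyl gives a 1.2-fold lower number from compound 1 to compound 4 (0.07 log units; within the scatter) and is the first measured change at this place, on an aromatic carbon para to a large group. The methoxy group is thus not needed to keep the number at the level of compound 1, and its loss stays within the scatter. No supporting measurement bears on this result.

Only methoxy and hydrogen are shown at this place. From the compounds shown here alone, whether an amine, a carboxylic acid or a longer chain there would leave the number level remains open.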